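From Compound 1 to Compound 3: One Added Carbonyl

This account rests on a few compounds, and the source may have more. Where it says the series, first, only, none or still open, it means among the compounds named here.

In a functional assay on SGC-7901 cells (Homo sapiens) for antiproliferative activity, read by MTT assay, with a stated time of 24 h (on this read-out lower numbers stand for stronger inhibition and higher numbers for weaker inhibition), compound 1 (`O=C(NNc1ccc(F)cc1)c1ccccc1NS(=O)(=O)c1cnc(O)nc1O`) gives > 20000 nM as a limit of the assay and not a number. In this assay compound 2 (`O=C(NNC(=O)c1ccccc1F)c1cccc(NS(=O)(=O)c2cnc(O)nc2O)c1`) gives > 20000 nM and this too is a limit. Compound 1 therefore has no number to its name, and its place is given by the limit of > 20000 nM in this assay, at which 2 of the 2 values shown sit, with no measured value to set the two compounds in order.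

Compound 3 (`O=C(NNC(=O)c1ccccc1NS(=O)(=O)c1cnc(O)nc1O)c1ccc(F)cc1`) keeps the core of compound 1 and changes one group, with (4-fluorophenyl)carbonyl in place of 4-fluorophenyl on an amine nitrogen. Within the data shown here, no measured step shows what such a change does in this assay, so no step beyond the usual scatter is expected in either direction. Among the measured compounds shown here, this expectation rests only on compound 1 at > 20000 nM as a limit and on the single change. The expected step is a step that the limit leaves unreadable from compound 1 to compound 3 on this estimate. For compound 3 the estimate is 25000 nM with an expected range from 6000 nM to 60000 nM and the assay may well report only a limit again.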

Compound 3, half-maximal inhibitory concentration: > 20000 nM
Compound 3 ended at the assay's limit; the forecaster's own chance of this, stated with the estimate: 65%; the middle value lies beyond the limit too.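

In this assay compound 3 gives > 20000 nM, a limit of the assay and not a number. Compound 1 and compound 3 both stand at a limit, so no step between them can be read: the limit of > 20000 nM in this assay, at which 3 of the 3 values shown sit.

The compounds shown leave open what (4-fluorophenyl)carbonyl in place of 4-fluorophenyl does in this assay, and whether any of these compounds would give a measured number there.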